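From benzyloxy to bromo in a small series

A few compounds are considered here, and "the series" means these few. Any claim that something is new, unique, unknown or untested is made for them only; others in the source may bear on it.

Compound 1 `COc1ccc(C2=NN(C(=O)c3ccc(C)nc3)C(c3ccc(OCc4ccccc4)cc3)C2)cc1` gives 7950 nM
Compound 2 `O=C(c1cccnc1Cl)N1N=C(c2ccc(Cl)cc2)CC1c1ccc(OCc2ccccc2)cc1` gives 7710 nM
Compound 3 `Cc1ccc(C(=O)N2N=C(c3ccc(Cl)cc3)CC2c2ccc(OCc3ccccc3)cc2)cn1` gives 9200 nM

All three compounds were read in a functional assay on WM 266-4 cells (Homo sapiens) for antiproliferative activity, read by MTT assay, with a stated time of 24 h (on this read-out lower numbers stand for stronger inhibition of growth and higher numbers for weaker inhibition of growth), and their values lie close together. The steps of a 1.2-fold higher number from compound 1 to compound 3 (0.06 log units; within the scatter) and a 1.2-fold higher number from compound 2 to compound 3 (0.08 log units; within the scatter) leave compound 3 with no separate place among them. Compound 4 `Cc1ccc(C(=O)N2N=C(c3ccc(Cl)cc3)CC2c2ccc(Br)cc2)cn1` carries bromo in place of benzyloxy on an aromatic carbon and awaits measurement. Neither measured step touches that place, so the data give no size or direction for this change. The expectation therefore rests on compound 3 at 9200 nM and foresees no step beyond the scatter. The expected change is a 1.1-fold higher number from compound 3 to compound 4 (0.04 log units; within the scatter) and it remains uncertain. For compound 4 the estimated value is 10000 nM with an expected range from 3000 nM to 30000 nM in this assay as a deliberately wide expectation.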

Compound 4, concentration for 50% growth inhibition: 7650 nM
Estimate against measurement, compound 4: 1.3-fold (0.12 log units) above; the range from low to high includes it.
By their numbers in this assay, from the lowest: compounds 4, 2, 1 and 3 (each within the scatter of the next).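

In this assay, bromo in place of benzyloxy on an aromatic carbon, para to a large group, gives a 1.2-fold lower number from compound 3 to compound 4 (0.08 log units; within the scatter). A single bromine atom thus takes the place of the whole benzyloxy group, with its six-membered aromatic ring, without a step beyond the scatter, so the ring is not needed for this level of growth inhibition in this series. No measurement offered here explains this result.

The compounds shown leave open whether an amine, a carboxylic acid or a longer alkoxy chain at this place would also stay within the scatter. They also leave open whether bromo gives the same result alongside the 2-chloropyridin-3-yl group on the carbonyl carbon.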